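The source may hold more compounds than are shown below. What is called first, only, known or untested is meant among the compounds shown, and "the series" means these compounds.

Compound 1, `CCc1ccc(C2=NN(c3ccc(S(C)(=O)=O)cc3)C(=O)CC2)cc1`, in a functional assay on the whole organism (strain Wistar) for inhibition, with Rattus norvegicus as the target, read by paw edema, with stated times of 30 min and 3 h, at a dose of 0.05 mmol/kg by the oral route (on this read-out lower numbers stand for less inhibition and higher numbers for more inhibition at the one dose given (going by the name of the read-out)), gives 46.7%.
Compound 2, `Cc1ccc(O)c(C2=NN(c3ccc(S(C)(=O)=O)cc3)C(=O)CC2)c1`, in this assay gives 66.6%.

Among the measured compounds shown here, compound 2 stands highest of the two numbers known so far; its nearest neighbour is compound 1, and the step of a number 19.9 percentage points higher from compound 1 to compound 2 (beyond the scatter) is modest but beyond the scatter. Compound 3, `CS(=O)(=O)c1ccc(N2N=C(c3ccc(O)c(Cl)c3)CCC2=O)cc1`, is not yet measured. It differs from compound 2 in one place: 3-chloro-4-hydroxyphenyl in place of 2-hydroxy-5-methylphenyl on a carbon with a double bond to nitrogen. For the measured compounds named here, the only measured step is the one from compound 1 to compound 2, and it bears on this change only loosely, since it exchanged one aryl group for another at the same carbon with a double bond to nitrogen, while the pair of aryl groups involved here is a different one. Both compound 2 and compound 3 carry a hydroxyl on that ring, whereas compound 1 carries none, so the known step gives little guidance on the size or direction of the change. The expected step here is a number 8.6 percentage points lower from compound 2 to compound 3 (within the scatter). Compound 3 is therefore estimated at 58% in this assay, with a range from 38% to 78%.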

Compound 3, a percentage reported as inhibition, in the whole organism at one dose (the size of the read-out at that dose, not a potency): 43.3%
Estimate against measurement, compound 3: 14.7 percentage points above; measured number inside the range.
By their numbers in this assay, from the lowest: compounds 3 and 1 (each within the scatter of the next); then compound 2.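

In this assay, the aryl group on the carbon with a double bond to nitrogen still matters when a hydroxyl stays on that ring: putting 3-chloro-4-hydroxyphenyl in place of 2-hydroxy-5-methylphenyl gives a number 23.3 percentage points lower from compound 2 to compound 3 (beyond the scatter). With a number 3.4 percentage points lower from compound 1 to compound 3 (within the scatter), 3-chloro-4-hydroxyphenyl and 4-ethylphenyl cannot be told apart at this position, so compound 3 goes against any reading that a hydroxyl on this ring by itself brings the higher number of compound 2. Nothing available explains why these two hydroxyl-bearing groups part in this way.

The two groups differ both in where the hydroxyl sits and in carrying a methyl or a chlorine, and the compounds shown do not separate these two changes. Also open, going by these compounds, is how an amine or a carboxylic acid on this ring, or a chain longer than the ethyl of compound 1, would read in this assay.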